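The source may hold more compounds than are shown below. What is called first, only, known or untested is meant among the compounds shown, and "the series" means these compounds.

Compound 2, `Cn1nc2c(=O)n(CC3(O)CCN(Cc4ccc(-c5ccco5)cc4Cl)CC3)cnc2c1-c1ccc(CNCCO)cc1`, gives the lowest number of the two measured in an assay on isolated protein for inhibition of ubiquitin carboxyl-terminal hydrolase 7 (Homo sapiens), with stated times of 30 min and 2 h (on this read-out lower numbers stand for stronger inhibition and higher numbers for weaker inhibition), namely 8.2 nM. Its nearest neighbour is compound 1, `Cn1nc2c(=O)n(CC3(O)CCN(Cc4ccc(-c5ccncc5)cc4Cl)CC3)cnc2c1-c1ccc(CN)cc1`, which in this assay gives 257 nM, a gap well beyond the scatter; as the two compounds differ in more than one place, that gap is simply what the two values show. Compound 3, `Cn1nc2c(=O)n(CC3(O)CCN(Cc4ccc(-c5ccco5)cc4Cl)CC3)cnc2c1-c1ccc(C(=N)N)cc1`, has not yet been measured in this assay. It differs from compound 2 in one place: a group of 3 heavy atoms (1 carbon, 2 nitrogen; no ring) in place of a group of 5 heavy atoms (3 carbon, 1 nitrogen, 1 oxygen; no ring), on an aromatic carbon. Going by the values given here, no comparable single step is available among the measured compounds, so the size of the step is uncertain; a modest weakening is expected, a 3.7-fold higher number from compound 2 to compound 3 (0.56 log units; beyond the scatter), since the strong value of compound 2 at 8.2 nM rests on the larger group. Compound 3 is therefore estimated at 30 nM, within a range of 6 nM to 200 nM.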

Compound 3, half-maximal inhibitory concentration: 87.5 nM
Estimate against measurement, compound 3: 2.9-fold (0.46 log units) below; measured number inside the range.
By their numbers in this assay, from the lowest: compound 2; then compound 3; then compound 1.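

In this assay, going by these compounds alone, this is the first step that can be read at this position, on an aromatic carbon para to a large group, and swapping the ((2-hydroxyethyl)amino)methyl group for the smaller group of 3 heavy atoms gives an 11-fold higher number from compound 2 to compound 3 (1.03 log units; beyond the scatter). The position therefore does not tolerate this change without a large loss, even though the two groups carry the same count of hydrogen-bond donors. No measurement shown here accounts for the size of this step.

The compounds shown leave open how an aminomethyl group, a longer chain such as a (3-hydroxypropyl)aminomethyl group, or a carboxylic acid would behave at this position on the core of compound 2. They also leave open whether a step of this size would hold with a different group at the far end of the molecule.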